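From trifluoromethyl to methoxy in compound 3

The source may hold more compounds than are shown below. What is called first, only, known or untested is meant among the compounds shown, and "the series" means these compounds.

Compound 1 `COc1ccc2nc(C)cc(SCc3ccccc3)c2c1`: 30600 nM
Compound 2 `COc1ccc2nc(C)cc(NCc3cc(F)cc(F)c3)c2c1`: 13300 nM
Compound 3 `COc1ccc2nc(C)cc(NCc3ccc(F)c(C(F)(F)F)c3)c2c1`: 11300 nM

All three compounds were tested in a functional assay on MCF-10A cells (Homo sapiens) for antiproliferative activity, with a stated time of 48 h; on this read-out higher numbers stand for an effect only at larger amounts of compound and lower numbers for an effect already at smaller amounts. There, compound 3 gives 11300 nM, which lies within the scatter of the value of compound 2 and beyond the scatter of the higher value of compound 1.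

The next compound to be measured is compound 4 `COc1ccc2nc(C)cc(NCc3ccc(F)c(OC)c3)c2c1`. It carries methoxy in place of trifluoromethyl on an aromatic carbon. Within the data shown here, no measured pair shows this exchange on its own, so the data give no direct size for it. Among the measured compounds shown here, the only guide is the narrow gap between compound 2 at 13300 nM and compound 3 at 11300 nM, which suggests no large move in this assay. A small shift toward a higher number is expected, most likely not beyond the scatter. The expected change is a 1.3-fold higher number from compound 3 to compound 4 (0.12 log units; within the scatter). For compound 4 the estimated value is 15000 nM, with an expected range from 6500 nM to 32000 nM.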

Compound 4, half-maximal effective concentration: 9500 nM
Compound 4: the middle estimate sits 1.6-fold (0.20 log units) above what was measured; measured number inside the range.
By their numbers in this assay, from the lowest: compounds 4, 3 and 2 (each within the scatter of the next); then compound 1.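

In this assay, among these compounds, the exchange can now be read directly for the first time: methoxy in place of trifluoromethyl on an aromatic carbon, ortho to a fluoro group, gives a 1.2-fold lower number from compound 3 to compound 4 (0.08 log units; within the scatter) and so stays inside the usual scatter. At this position, a group of 4 heavy atoms with no hydrogen-bond acceptor can thus give way to one of 2 heavy atoms with 1 hydrogen-bond acceptor without a measurable move on this read-out. Nothing in the available data offers a reason for this outcome.

Going by these compounds, whether an amine, a carboxylic acid or a longer chain on the same carbon would also stay within the scatter remains open. So does whether this exchange would behave the same way without the fluoro group.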